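The source may report more compounds than this note shows. Statements on the series, on what has been measured and on what is new or still open speak of the compounds shown alone.

Compound 1 `CCn1c(CNc2ccccc2)nnc1SCC(=O)Nc1ccc(OC)cc1`: in an assay on isolated protein for inhibition of long-chain fatty acid transport protein 1 (Mus musculus) (a higher number here means a weaker inhibitor, a lower number a stronger inhibitor), compound 1 gives > 10000 nM, which is a limit of the assay and not a number.
Compound 2 `CCn1c(CNc2ccccc2)nnc1SCc1nc2cc(C(=O)C(C)C)ccc2o1`: in this assay compound 2 gives 520 nM.
Compound 3 `CCOC(=O)c1ccc(NC(=O)CSc2nnc(CSCc3ccccc3)n2CC)cc1`: in this assay compound 3 gives > 10000 nM, again a limit of the assay.

Compound 1 therefore stands at the upper edge of what this assay reports. Two of the three values shown sit at that same limit (the limit of > 10000 nM in this assay, at which 2 of the 3 values shown sit), and only compound 2 gives a number. Compound 4 `CCn1c(CNc2ccccc2)nnc1SCC(=O)Nc1ccc(Cl)cc1` differs from compound 1 by chloro in place of methoxy on an aromatic carbon. Within the data shown here, no step between two measured compounds is available for comparison, so the size of this change cannot be read from the data. With compound 1 already at the limit, the step from compound 1 to compound 4 is expected to be small, either direction, and not beyond the usual scatter. Compound 4 is accordingly expected to give 15000 nM, within a range of 5000 nM to 50000 nM. That estimate means a step that the limit leaves unreadable from compound 1 to compound 4, which is expected to stay within the scatter of repeated measurements, and most likely compound 4 will again be reported only as a limit.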

Compound 4, half-maximal inhibitory concentration: > 10000 nM
Compound 4 was reported as a limit; the forecaster's own chance of this, stated with the estimate: 70%; the middle value lies beyond the limit too.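

Compound 1 and compound 4 are both reported only as limits, so the change from methoxy to chloro yields no readable step: the limit of > 10000 nM in this assay, at which 3 of the 4 values shown sit.

The compounds shown leave open how far either group affects binding in this assay, and which structural feature gives compound 2 its measured value of 520 nM.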